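The source may hold more compounds than are shown below. What is called first, only, known or untested is meant among the compounds shown, and "the series" means these compounds.

Working notes on the series, with a functional assay on NCI-H460 cells (Homo sapiens) for antiproliferative activity, read by sulforhodamine B assay, with a stated time of 48 h (on this read-out higher numbers stand for weaker inhibition of growth and lower numbers for stronger inhibition of growth), as the only read-out so far. Compound 2 `C#CCOc1ccc(/C=C/C(C)=O)cc1OC` gives 52700 nM and sits within the scatter of compound 1 `C=CCOc1ccc(/C=C/C(C)=O)cc1OC`, which gives 41500 nM on the same read-out. With only these two numbers, compound 2 has no separate standing in the series.

Compound 3 `COC(=O)COc1ccc(/C=C/C(C)=O)cc1OC` follows from compound 2 through the change methoxycarbonyl in place of ethynyl on a saturated chain carbon bound to an oxygen on an aromatic ring on a saturated chain carbon bound to an oxygen on an aromatic ring, which reads as propargyloxy to (methoxycarbonyl)methoxy. For the measured compounds named here, the one measured step at this place is a 1.3-fold higher number from compound 1 to compound 2 (0.10 log units; within the scatter) and it replaces vinyl with ethynyl. Going by the values given here, no measured compound carries methoxycarbonyl, so that small step is weak guidance for the new group.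

The expectation in this assay is therefore no shift beyond the scatter in either direction, anchored on compound 2 at 52700 nM and held with a wide range. The expected move is a 1.1-fold lower number from compound 2 to compound 3 (0.02 log units; within the scatter) and no clear direction is implied. For compound 3 the estimate is 50000 nM within an expected range from 20000 nM to 120000 nM on present data.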

Compound 3, concentration for 50% growth inhibition: > 150000 nM
Compound 3 was reported as a limit; the forecaster's own chance of this, stated with the estimate: 15%; middle value at least 3.0-fold (0.47 log units) from the limit.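

In this assay, the substituent on a saturated chain carbon bound to an oxygen on an aromatic ring now shows that it can matter: vinyl and ethynyl stayed within the scatter of each other, whereas methoxycarbonyl gives an at least 2.8-fold higher number from compound 2 to compound 3 (0.45 log units; beyond the scatter) and an at least 3.6-fold higher number from compound 1 to compound 3 (0.55 log units; beyond the scatter). Compound 3 is reported as a limit of the assay, so the size of both steps is bounded from one side only: the limit of > 150000 nM in this assay, at which 1 of the 3 values shown sits. The change brings in methoxycarbonyl, with 4 heavy atoms and 2 hydrogen-bond acceptors, but this single compound cannot show which feature of the group goes with the weaker inhibition of growth.

The compounds shown leave open whether this loss belongs to methoxycarbonyl in particular or extends to other groups at this place, and a carboxylic acid, a primary amide or a plain ethyl chain would help to separate these readings. On these data alone, how far compound 3 lies past its limit also stays open, and with it the true size of both steps.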